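This account rests on a few compounds, and the source may have more. Where it says the series, first, only, none or still open, it means among the compounds named here.

Compound 1, `CC(C)(C)c1ccc(-c2nc(CN3CCC(C(=O)c4ccc5c(c4)OCCO5)CC3)co2)cc1`: in an ADME assay on HEK293 cells (Homo sapiens) for cytotoxicity, read by MTT assay, with a stated time of 36 h (a higher number here means a weaker inhibitor, a lower number a stronger inhibitor), compound 1 gives > 150 ug/mL, which is a limit of the assay and not a number.
Compound 2, `CC(C)(C)c1ccc(-c2nc(CN3CCC(C(=O)c4ccc5c(c4)OCCO5)CC3)cs2)cc1`: in this assay compound 2 gives "not determined" (no result reported).
Compound 3, `O=C(c1ccccc1)C1CCN(Cc2coc(-c3ccc(F)cc3)n2)CC1`: in this assay compound 3 gives > 150 ug/mL, again only a limit, not a number.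

Where compound 3 stands is therefore only partly known. Its result in this assay is a limit, and of the two further entries one is also a limit while the other carries no number at all. For the measured compounds named here, the one thing the numbers say is captured by the limit of > 150 ug/mL in this assay, at which 2 of the 3 values shown sit: none of the compounds with a result reached a measurable cytotoxicity within the range tested.

The step to compound 4, `COc1ccc(C(=O)C2CCN(Cc3coc(-c4ccc(F)cc4)n3)CC2)cc1`, is a single change on the phenyl ring of the ketone: methoxy in place of hydrogen on an aromatic carbon. Going by the values given here, no step between two measured compounds is available to gauge what such a change does here, so the expectation rests on the pattern of limits alone. Compound 3 sits at the limit, and the addition of a methoxy group is expected to move the result by nothing beyond the usual scatter, so the step from compound 3 to compound 4 is estimated as a number no higher from compound 3 to compound 4 (the limit leaves the size open).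

For compound 4 in this assay the estimate is 150 ug/mL, with a range from 80 ug/mL to 300 ug/mL, and most likely the assay will again report only a limit.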

Compound 4, half-maximal inhibitory concentration: > 150 ug/mL
Compound 4: no number, only a limit; the forecaster's own chance of this, stated with the estimate: 70%; the middle value sits exactly at the limit.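

Compound 3 and compound 4 each give only a limit of the assay, not a number, in this assay, so no step can be read for methoxy in place of hydrogen. The compounds shown leave open the concentration at which any of them would show cytotoxicity, as the results stop at one shared limit: the limit of > 150 ug/mL in this assay, at which 3 of the 4 values shown sit.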